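A wider benzyl group on the shared core

The source may hold more compounds than are shown below. What is called first, only, known or untested is meant among the compounds shown, and "the series" means these compounds.

Measured so far in a functional assay on A2780 cells (Homo sapiens) for inhibition, read by MTT assay, with a stated time of 72 h (on this read-out higher numbers stand for weaker inhibition and lower numbers for stronger inhibition), are two compounds:
Compound 1 `O=C1/C(=C\c2ccccc2)c2c(ncn2COCc2ccccc2)CCN1Cc1ccc(F)cc1` gives 24800 nM
Compound 2 `Cc1cccc(CN2CCc3ncn(COCc4ccccc4)c3/C(=C/c3ccccc3)C2=O)c1` gives 26300 nM

Among the compounds with values here, compound 2 sits level with compound 1, the only other measured compound, and the two cannot be told apart in this assay on these numbers. Compound 3 `CC(C)(C)c1ccc(CN2CCc3ncn(COCc4ccccc4)c3/C(=C/c3ccccc3)C2=O)cc1` remains unmeasured. Its change from compound 2 is 4-(tert-butyl)phenyl in place of 3-methylphenyl on a saturated chain carbon bound to an amide-type nitrogen in a ring and in words it is 4-(tert-butyl)phenyl in place of 3-methylphenyl on a saturated chain carbon bound to an amide-type nitrogen in a ring. Within the data shown here, one measured step bears on this, the exchange of 4-fluorophenyl for 3-methylphenyl at the same place, which came to a 1.1-fold higher number from compound 1 to compound 2 (0.03 log units; within the scatter) and so stayed small. Among the measured compounds shown here, it is a single step, and no measured compound carries 4-(tert-butyl)phenyl. No step beyond the scatter is therefore expected in this assay and the expected size is a 1.1-fold lower number from compound 2 to compound 3 (0.04 log units; within the scatter) by this estimate. For compound 3 the estimated value is 24000 nM with an expected range from 10000 nM to 50000 nM as its likely span.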

Compound 3, half-maximal inhibitory concentration: 23900 nM
The estimate for compound 3 lay 1.0-fold (0.00 log units) above the measured number, within the range that was stated.
By their numbers in this assay, from the lowest: compounds 3, 1 and 2 (each within the scatter of the next).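

In this assay, the change from 3-methylbenzyl to 4-(tert-butyl)benzyl gave a 1.1-fold lower number from compound 2 to compound 3 (0.04 log units; within the scatter), and tert-butyl in place of fluoro on an aromatic carbon gave a 1.0-fold lower number from compound 1 to compound 3 (0.02 log units; within the scatter). The place on a saturated chain carbon bound to an amide-type nitrogen in a ring thus accepts a substituent of 10 heavy atoms as readily as one of 7, and all three compounds remain level, so no benzyl group shown stands apart. No measurement at hand accounts for this lack of change.

All the compounds shown keep a substituted benzyl group, so they leave open whether a carboxylic acid or an amine on that ring, or a plain methyl in place of the whole benzyl group, would move the number. They also do not show whether any change at this place can produce a step beyond the scatter.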